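A chloro group added to the 2-methylphenyl amide

A few compounds are considered here, and "the series" means these few. Any claim that something is new, unique, unknown or untested is made for them only; others in the source may bear on it.

In a functional assay on A549 cells (Homo sapiens) for cytotoxicity, read by MTT assay, with a stated time of 72 h (on this read-out higher numbers stand for weaker inhibition and lower numbers for stronger inhibition), three compounds share one core and differ only in the group on the amide-type nitrogen. Compound 1 `O=C(CN1CCN(c2nnc(Cc3ccncc3)c3ccccc23)CC1)Nc1cccc(F)c1`, with 3-fluorophenyl, gives 4600 nM. Compound 2 `O=C(CN1CCN(c2nnc(Cc3ccncc3)c3ccccc23)CC1)Nc1ccc(F)c(C(F)(F)F)c1`, with 4-fluoro-3-(trifluoromethyl)phenyl, gives 16000 nM. Compound 3 `Cc1ccccc1NC(=O)CN1CCN(c2nnc(Cc3ccncc3)c3ccccc23)CC1`, with 2-methylphenyl, gives 43100 nM, the highest number of the three and so the weakest inhibition.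

Compound 4 `Cc1cccc(Cl)c1NC(=O)CN1CCN(c2nnc(Cc3ccncc3)c3ccccc23)CC1` makes one change to compound 3: chloro in place of hydrogen on an aromatic carbon. This puts chloro in place of hydrogen on an aromatic carbon, ortho to a large group and meta to a methyl group, giving 2-chloro-6-methylphenyl.

Among the measured compounds shown here, no measured step adds a group in this way, and no measured compound carries chloro. The nearest evidence comes from swaps of the whole group: a 9.4-fold higher number from compound 1 to compound 3 (0.97 log units; beyond the scatter) and a 2.7-fold higher number from compound 2 to compound 3 (0.43 log units; beyond the scatter). Both fluorine-bearing compounds therefore sit lower than compound 3, which weakly suggests a modest move towards a lower number in this assay. The estimated step is a 1.7-fold lower number from compound 3 to compound 4 (0.24 log units; within the scatter). Compound 4 is expected at about 25000 nM, with an estimated range of 8000 nM to 70000 nM.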

Compound 4, half-maximal inhibitory concentration: 7190 nM
For compound 4 the middle estimate is 3.5-fold (0.54 log units) above the measured one, outside the stated range (below it).
By their numbers in this assay, from the lowest: compounds 1 and 4 (each within the scatter of the next); then compound 2; then compound 3.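

In this assay, a single chloro on the 2-methylphenyl group is the first change shown that adds one atom to the amide-side ring rather than swapping the whole group, and this one atom gives a 6.0-fold lower number from compound 3 to compound 4 (0.78 log units; beyond the scatter). The new compound also moves clear of the 4-fluoro-3-(trifluoromethyl)phenyl compound (a 2.2-fold lower number from compound 2 to compound 4 (0.35 log units; beyond the scatter)) and comes to sit with the 3-fluorophenyl compound (a 1.6-fold higher number from compound 1 to compound 4 (0.19 log units; within the scatter)), so a methyl group on this ring does not by itself tie a compound to the highest number. Nothing measured here accounts for why chloro does this.

Going by these compounds, it remains open whether chloro itself matters or whether any added group would do, such as a methoxy group or an amine, ortho to a large group and meta to a methyl group. On these data alone, it is equally open whether chloro would give a similar step on a ring without the methyl group.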